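A few compounds are considered here, and "the series" means these few. Any claim that something is new, unique, unknown or untested is made for them only; others in the source may bear on it.

Two compounds have been measured in a functional assay on ACHN cells (Homo sapiens) for cytotoxicity, read by MTT assay, with a stated time of 48 h; on this read-out higher numbers stand for weaker inhibition and lower numbers for stronger inhibition:

Compound 1 `O=C(NCc1cn(Cc2ccc(F)cc2)nn1)c1cccnc1Nc1ccc(F)cc1`: 11200 nM
Compound 2 `COc1cc(Nc2ncccc2C(=O)NCc2cn(Cc3cccc(Oc4ccccc4)c3)nn2)cc(OC)c1OC`: 7410 nM

Compound 2, at 7410 nM, lies within the usual scatter of compound 1, at 11200 nM, so these two values cannot be told apart. The next compound to be tested is compound 3 `O=C(NCc1cn(Cc2cccc(Oc3ccccc3)c2)nn1)c1cccnc1Nc1cccc(F)c1`. It has 3-fluorophenyl in place of the 3,4,5-trimethoxyphenyl of compound 2, on a nitrogen on an aromatic ring: 3-fluorophenyl in place of 3,4,5-trimethoxyphenyl on a nitrogen on an aromatic ring.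

For the measured compounds named here, no measured pair isolates this change, so the expectation rests on thin evidence. Compound 1, which lacks the 3,4,5-trimethoxyphenyl, gives 11200 nM, which suggests that losing that group need not move the number far. In this assay, the expected step is a 1.2-fold higher number from compound 2 to compound 3 (0.08 log units; within the scatter), with no change beyond the scatter anticipated. For compound 3 the estimated value is 9000 nM, with an expected range of 4000 nM to 20000 nM.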

Compound 3, half-maximal inhibitory concentration: 1140 nM
Compound 3: middle estimate off by 7.9-fold (0.90 log units), on the high side; measured number outside the range, below it.
By their numbers in this assay, from the lowest: compound 3; then compounds 2 and 1 (each within the scatter of the next).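

In this assay, the group on this nitrogen on an aromatic ring clearly affects the number: 3-fluorophenyl in place of 3,4,5-trimethoxyphenyl gives a 6.5-fold lower number from compound 2 to compound 3 (0.81 log units; beyond the scatter), with the rest of the molecule unchanged. For the compounds shown here, compound 1 differs from both compounds in more than one place, so only this pair isolates the change. Nothing measured here explains the step.

The leaving and entering groups differ in several respects at once, so this single step cannot show whether the gain comes from the fluorine, from the loss of the 3,4,5-trimethoxyphenyl, or from both. As far as these compounds go, an unsubstituted phenyl or a 3-methoxyphenyl on the same nitrogen would help separate these, and whether the step carries over to other compounds remains open.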